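The source may report more compounds than this note shows. Statements on the series, on what has been measured and on what is new or still open speak of the compounds shown alone.

Series notes. For the measured compounds named here, compound 1 `O=C(O)c1cccc(CNc2cc(C(F)(F)F)cc3[nH]ncc23)c1` is one of two compounds so far tested in an assay for inhibition of Tryptophan 2,3-dioxygenase (Homo sapiens), with stated times of 10 min and 60 min, tested at 100 uM; a lower number here means a weaker effect, a higher number a stronger effect of the compound at the concentration tested; in that assay compound 1 gives 94%, and compound 2 `Oc1ccc(CNc2cc(C(F)(F)F)cc3[nH]ncc23)c(Cl)c1` gives 97%, the two numbers lying within the scatter of each other, so no order between them is claimed. The next compound, compound 3 `FC(F)(F)c1cccc(CNc2cc(C(F)(F)F)cc3[nH]ncc23)c1`, differs from compound 1 in one place: trifluoromethyl in place of carboxy on an aromatic carbon. Going by the values given here, with no comparable step among measured pairs, the size of the effect is open; given that compound 2 holds 97% without a carboxy, the expected step is a number 9 percentage points lower from compound 1 to compound 3 (within the scatter), small. Compound 3 is expected to give 85% (range 60% to 98%).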

Compound 3, a percentage reported as inhibition, at one concentration (the size of the read-out at that concentration, not a potency): 74%
For compound 3 the middle estimate is 11 percentage points above the measured one, within the range that was stated.
By their numbers in this assay, from the lowest: compound 3; then compounds 1 and 2 (each within the scatter of the next).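

Replacing carboxy with trifluoromethyl on this aromatic carbon is not a neutral swap in this assay: the change gives a number 20 percentage points lower from compound 1 to compound 3 (beyond the scatter), so the read-out responds to the group at this position. Even so, compound 3 retains 74% without the carboxy. Nothing available on these compounds explains the step.

From the compounds shown here alone, whether the step reflects losing carboxy or gaining trifluoromethyl stays open. A nitrile, a primary amide or a plain hydrogen on the same aromatic carbon would help separate the two.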